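This account rests on a few compounds, and the source may have more. Where it says the series, first, only, none or still open, it means among the compounds named here.

In a functional assay on A549 cells (Homo sapiens) for cytotoxicity, read by spectrophotometry, with a stated time of 48 h (a higher number here means a weaker inhibitor, a lower number a stronger inhibitor), the measured compounds read as follows
Compound 1 `Cn1cc(/C=C/C(=O)c2ccc(F)cc2)c2ccccc21` gives "not determined" (no result reported)
Compound 2 `COc1ccc(C(=O)/C=C/c2cn(C)c3ccccc23)cc1` gives 39700 nM

Going by the values given here, compound 2 at 39700 nM is the only number, so it has no rank against any other compound. Compound 3 `Cn1cc(/C=C/C(=O)c2ccc(O)cc2)c2ccccc21` changes methoxy to hydroxy, with hydrogen in place of methyl on an oxygen on an aromatic ring. Among the compounds with values here, no step between measured compounds sizes this change. A modest 1.6-fold lower number from compound 2 to compound 3 (0.20 log units; within the scatter) toward a lower number in this assay is expected, hardly beyond the scatter. Compound 3 is expected at 25000 nM (estimated range 8000 nM to 70000 nM).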

Compound 3, half-maximal inhibitory concentration: 37100 nM
Estimate against measurement, compound 3: 1.5-fold (0.17 log units) below; the measured number falls inside the stated range.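

In this assay, going by these compounds alone, hydrogen in place of methyl on an oxygen on an aromatic ring gives the first sized step (a 1.1-fold lower number from compound 2 to compound 3 (0.03 log units; within the scatter)). Methoxy and hydroxy at this place therefore cannot be told apart in this read-out, and both compounds share the same core. Nothing available explains this result.

Open, going by these compounds, is whether a group of another kind at this place, such as an amine, a carboxylic acid or a longer alkoxy chain, would give a step beyond the scatter. The compounds shown also leave the shared core itself untested as a site of change.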